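The compounds below may be only part of what the source reports. "The series", "measured", "known", "first", "only" and "open" are said of these compounds alone.

Of the compounds shown here, three have been tested in a functional assay on HT-29 cells (Homo sapiens) for cytotoxicity, read by sulforhodamine B assay, with a stated time of 48 h, tested at 10 uM; on this read-out higher numbers stand for a weaker effect at the one concentration tested and lower numbers for a stronger effect. Compound 1 `COc1ccc(-c2cc(/C=C/C(=O)c3ccc(N)cc3)[nH]n2)cc1` gives -10%, and compound 2 `COc1ccc(-c2cc(/C=C/C(=O)c3ccc(N)cc3)[nH]n2)cc1OC` gives -19%. These two share a core and differ in one place, namely (hydrogen in place of methoxy on an aromatic carbon); the step of a number 9 percentage points higher from compound 2 to compound 1 (within the scatter) is within the scatter, so the two read-outs cannot be told apart. Compound 3 `COc1cc(C(=O)/C=C/c2cc(-c3cc(OC)c(OC)c(OC)c3)n[nH]2)cc(OC)c1OC` is built differently; how its core differs from that of compound 2 is not broken down here. In this assay compound 3 gives -86%, the lowest of the three numbers and beyond the scatter from both others.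

Compound 4 `COc1ccc(-c2cc(/C=C/C(=O)c3cc(OC)c(OC)c(OC)c3)[nH]n2)cc1OC` has not yet been measured. It comes from compound 3 by hydrogen in place of methoxy on an aromatic carbon. This is the same kind of change as that from compound 2 to compound 1, though the surroundings are not identical: here the place is also meta to a methoxy group, which was not so before. Since the earlier step was within the scatter, a modest step is expected, yet compound 3 stands far from the rest, so the outcome is uncertain; the estimated step is a number 26 percentage points higher from compound 3 to compound 4 (beyond the scatter). For compound 4 a value around -60% is expected.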

Compound 4, a percentage reported as activity, at one concentration (the size of the read-out at that concentration, not a potency): -87%
Compound 4: middle estimate off by 27 percentage points, on the high side; the range from low to high includes it.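

Removing this methoxy group in favour of hydrogen gives a number 1 percentage points lower from compound 3 to compound 4 (within the scatter) in this assay, so compound 3 and compound 4 cannot be told apart on this read-out. Set beside the earlier pair, the same change behaves alike on the two cores, with no measurable effect on either: the same change on two cores in this assay, a number 9 percentage points higher (within the scatter) from compound 2 to compound 1 and a number 1 percentage points lower (within the scatter) from compound 3 to compound 4, 10 percentage points apart, within the scatter of two such steps

Within the data shown here, this agreement rests on only two pairs, so it does not show that the change would stay without effect on a further core, and it does not explain why compound 3 and compound 4 stand so far from compound 1 and compound 2, which differ from them in more than one place.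

The compounds shown leave open what other groups would do in place of this methoxy group, such as a hydroxyl group, a chlorine atom or a longer ethoxy chain. They also leave open how far the amine of compound 1 and compound 2 matters, which a pair differing only in that group, for example with an amide in its place, could test.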